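Truncating the amide substituent in the dienamide series

A few compounds are considered here, and "the series" means these few. Any claim that something is new, unique, unknown or untested is made for them only; others in the source may bear on it.

Compound 1 `COc1ccc(CNC(=O)/C=C/C=C/[C@H](O)Cc2ccc(OC)c(OC)c2)cc1` carries the 4-methoxybenzyl amide. In a functional assay on MCF7 cells (Homo sapiens) for antiproliferative activity, read by sulforhodamine B assay, with a stated time of 48 h (on this read-out higher numbers stand for weaker inhibition and lower numbers for stronger inhibition), compound 1 gives 26600 nM, the highest of the three numbers shown. Compound 2 `COc1ccc(C[C@@H](O)/C=C/C=C/C(=O)N2CCN(c3ccccn3)CC2)cc1OC` gives 23600 nM, which sits within the scatter of compound 1. Compound 3 `COc1ccc(C[C@@H](O)/C=C/C=C/C(=O)N2CCN(c3ccccc3)CC2)cc1OC` gives 12000 nM, and its gap to compound 1 lies beyond the scatter. Among the compounds with values here, the only measured step, a 2.0-fold lower number from compound 2 to compound 3 (0.29 log units; within the scatter), concerns the amine nitrogen in a ring and does not bear on the amide substituent. Compound 4 `CCNC(=O)/C=C/C=C/[C@H](O)Cc1ccc(OC)c(OC)c1` differs from compound 1 by methyl in place of 4-methoxyphenyl on a saturated chain carbon bound to an amide-type nitrogen. Within the data shown here, no measured step addresses this change, so no step beyond the scatter is expected in this assay. The expected step is a 1.3-fold higher number from compound 1 to compound 4 (0.12 log units; within the scatter). Compound 4 is therefore estimated at 35000 nM, with a range from 12000 nM to 100000 nM.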

Compound 4, half-maximal inhibitory concentration: 12900 nM
The estimate for compound 4 lay 2.7-fold (0.43 log units) above the measured number; measured number inside the range.
By their numbers in this assay, from the lowest: compounds 3, 4, 2 and 1 (each within the scatter of the next, the first and the last beyond it).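

In this assay, cutting 4-methoxybenzyl back to ethyl gives a 2.1-fold lower number from compound 1 to compound 4 (0.31 log units; beyond the scatter), the first step read at the amide substituent itself. The 4-methoxyphenyl is therefore not needed to hold this level of activity, and its loss does not raise the number. Nothing available gives a reason for this modest step.

Open, as far as these compounds go, is whether a longer chain such as butyl, or an amine or carboxylic acid carried on the ethyl group, would shift the number further. Also open, from the compounds shown here alone, is how plain benzyl would compare with 4-methoxybenzyl.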